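This account rests on a few compounds, and the source may have more. Where it says the series, first, only, none or still open, it means among the compounds named here.

Compound 1 `C=CCOc1c(Cl)cccc1C(=O)c1cccnc1` and compound 2 `O=C(c1cccnc1)c1cccc(Cl)c1O` share one core and differ in a single place, (hydrogen in place of allyl on an oxygen on an aromatic ring). In a functional assay on IMR-32 cells (Homo sapiens) for cytotoxicity, read by sulforhodamine B assay, with a stated time of 48 h (on this read-out lower numbers stand for stronger inhibition and higher numbers for weaker inhibition), compound 1 gives 94000 nM, while compound 2 gives 26000 nM, a step of a 3.6-fold lower number from compound 1 to compound 2 (0.56 log units; beyond the scatter). Compound 3 `C=CCOc1ccc(C)cc1C(=O)c1cccnc1` rests on another core; how that core differs from the core of compound 1 is not broken down here. In this assay compound 3 gives 87000 nM. Compound 4 `Cc1ccc(O)c(C(=O)c2cccnc2)c1` arises from compound 3 by the same change, (hydrogen in place of allyl on an oxygen on an aromatic ring), at a place described in the same words as before. Going by the values given here, for compound 4 a step of similar size is expected in this assay, a 3.6-fold lower number from compound 3 to compound 4 (0.56 log units; beyond the scatter), because the earlier step of a 3.6-fold lower number from compound 1 to compound 2 (0.56 log units; beyond the scatter) is the only guide available. Compound 4 is therefore estimated at 24000 nM, with a likely range from 10000 nM to 60000 nM.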

Compound 4, half-maximal inhibitory concentration: 5540 nM
The estimate for compound 4 lay 4.3-fold (0.64 log units) above the measured number; the measured number lies below the stated range.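

In this assay the change from allyl to hydrogen on the oxygen lowers the number again (a 16-fold lower number from compound 3 to compound 4 (1.20 log units; beyond the scatter)). The direction of the step carries over from one core to the other, but its size does not: the same change on two cores in this assay, a 3.6-fold lower number (0.56 log units; beyond the scatter) from compound 1 to compound 2 and a 16-fold lower number (1.20 log units; beyond the scatter) from compound 3 to compound 4, 4.3-fold (0.64 log units) apart, beyond the scatter of two such steps. These two pairs show that the size of this step cannot simply be copied between the two cores, but they do not show which difference between the cores matters, or what the step would be on a third core.

Still open, going by these compounds, is how a group other than allyl or hydrogen on this oxygen, such as methyl or a longer chain, would compare. An amine or a carboxylic acid carried at the end of such a chain also remains untested among the compounds shown here.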